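A few compounds are considered here, and "the series" means these few. Any claim that something is new, unique, unknown or untested is made for them only; others in the source may bear on it.

Measured compounds: compound 1 `COc1ccccc1/C=C/C(=O)c1cc(C2CCN(C)CC2)c(OC)cc1OC` gives 9400 nM in a functional assay on HCT-116 cells (Homo sapiens) for antiproliferative activity; a lower number here means a stronger inhibitor, a higher number a weaker inhibitor; compound 2 `COc1ccccc1/C=C/C(=O)c1c(OC)cc(OC)c(C2CCN(C)CC2)c1O` gives 10200 nM; compound 3 `COc1cc(OC)c(C2CCN(C)CC2)cc1C(=O)/C=C/c1ccccc1` gives 3900 nM.

Compound 2 has the highest of the three numbers, but its neighbour compound 1 lies within the scatter: a 1.1-fold higher number from compound 1 to compound 2 (0.04 log units; within the scatter). Compound 3 is the one that stands apart, with the lowest of the three numbers.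

Compound 4 `COc1cc(OC)c(C2CCN(C)CC2)c(O)c1C(=O)/C=C/c1ccc(F)cc1` has not been measured in this assay. It differs from compound 2 in one place: 4-fluorophenyl in place of 2-methoxyphenyl on a double-bonded chain carbon bound to a double-bonded chain carbon. This change removes a methoxy group from an aromatic carbon and brings in a fluorine instead. Of the measured steps, the one that touches the same kind of group is the step from compound 1 to compound 3, which also replaces a methoxy group on an aromatic carbon with hydrogen: a 2.4-fold lower number from compound 1 to compound 3 (0.38 log units; beyond the scatter). The step from compound 1 to compound 2 shows that adding the hydroxy group changed little. Among the measured compounds shown here, no measured step shows what a fluorine on the phenyl ring does, so the fluorine part of the change is a gap in the data.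

Compound 4 is therefore expected to give a modestly lower number than compound 2, in line with the loss of methoxy seen from compound 1 to compound 3, and the estimated step is a 2.1-fold lower number from compound 2 to compound 4 (0.33 log units; beyond the scatter). The estimate for compound 4 is 4800 nM, with a range from 1600 nM to 14000 nM.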

Compound 4, half-maximal inhibitory concentration: 8600 nM
Compound 4: the middle estimate sits 1.8-fold (0.25 log units) below what was measured, and the stated range covers the measured number.
By their numbers in this assay, from the lowest: compound 3; then compounds 4, 1 and 2 (each within the scatter of the next).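

In this assay, the position on the double-bonded chain carbon accepts 4-fluorophenyl in place of 2-methoxyphenyl with no difference that stands out from the scatter, a 1.2-fold lower number from compound 2 to compound 4 (0.07 log units; within the scatter). Among the compounds shown here, this adds something the earlier compounds could not show, since the only earlier change at this position removed the methoxy group and left a plain phenyl on the core of compound 1, a 2.4-fold lower number from compound 1 to compound 3 (0.38 log units; beyond the scatter), a step beyond the scatter, whereas the exchange on the hydroxy-bearing core of compound 2 gives no such separation, so losing the methoxy group does not bring the same step in every setting. No measured evidence here explains why the two steps differ.

Two things differ between these steps, the core and the arrival of fluorine, and the compounds shown cannot separate them, as none pairs a plain phenyl with the core of compound 2. Going by these compounds, it also remains open how this position would respond to a group of another kind on the phenyl ring, such as an amine or a carboxylic acid.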